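Chromone ethers with basic side chains: hydroxy removal step

The source may hold more compounds than are shown below. What is called first, only, known or untested is meant among the compounds shown, and "the series" means these compounds.

In an assay on isolated protein (Cavia porcellus) with Sigma non-opioid intracellular receptor 1 (Homo sapiens) as the target, read by radioligand binding (a lower number here means a stronger inhibitor, a higher number a weaker inhibitor), the measured compounds are:
compound 1 `CN(C)CCCCCCCCCCOc1ccc2oc(-c3ccccc3)cc(=O)c2c1`: 341 nM
compound 2 `O=c1cc(-c2ccccc2)oc2ccc(OCCCN3CCC(O)CC3)cc12`: 123 nM
compound 3 `O=c1cc(-c2ccccc2)oc2ccc(OCCCCCCN3CCC(O)CC3)cc12`: 121 nM

Compound 3 has the lowest number of the three, but it is separated from compound 2 only by a 1.0-fold lower number from compound 2 to compound 3 (0.01 log units; within the scatter), so the two cannot be ordered. Against compound 1 the separation is a 2.8-fold lower number from compound 1 to compound 3 (0.45 log units; beyond the scatter), and the parallel change on the shorter chain gave a 2.8-fold lower number from compound 1 to compound 2 (0.44 log units; beyond the scatter); both place compound 3 clearly apart from compound 1.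

Compound 4 `O=c1cc(-c2ccccc2)oc2ccc(OCCCCCCN3CCCCC3)cc12` differs from compound 3 by hydrogen in place of hydroxy on a saturated ring carbon. Within the data shown here, no measured step touches this hydroxy: the two steps from compound 1 exchange the whole terminal amine and the step from compound 2 alters only chain length. The measured steps therefore bear on it only loosely, showing that the series tolerates changes at the basic end with at most modest movement. A small step in this assay is expected, a 1.7-fold lower number from compound 3 to compound 4 (0.24 log units; within the scatter), and nothing large in either direction. For compound 4 the estimate in this assay is 70 nM, with a range from 20 nM to 250 nM.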

Compound 4, half-maximal inhibitory concentration: 54 nM
For compound 4 the middle estimate is 1.3-fold (0.11 log units) above the measured one, within the range that was stated.
By their numbers in this assay, from the lowest: compound 4; then compounds 3 and 2 (each within the scatter of the next); then compound 1.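

Replacing the hydroxy on this saturated ring carbon with hydrogen can now be read on its own: in this assay it gives a modest step beyond the scatter (a 2.2-fold lower number from compound 3 to compound 4 (0.35 log units; beyond the scatter)), so the hydroxy is not required for binding in this series. The piperidin-1-yl end also separates from the hydroxylated amine on the shorter chain (a 2.3-fold lower number from compound 2 to compound 4 (0.36 log units; beyond the scatter)) and from the dimethylamino end (a 6.3-fold lower number from compound 1 to compound 4 (0.80 log units; beyond the scatter)), and with all its steps beyond the scatter, compound 4 is the strongest of the four. Nothing at hand explains the effect of removing the hydroxy.

Going by these compounds, whether the same step holds on the shorter chain of compound 2 remains open. Also open, on these data alone, is how a methoxy, an amine or a carboxylic acid on this ring carbon would compare with hydrogen and hydroxy.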